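The source may report more compounds than this note shows. Statements on the series, on what has been measured and on what is new or still open speak of the compounds shown alone.

Measured compounds:
- compound 1, `COc1cc(/C=C/C(=O)c2cccc(-n3cc(-c4ccc(Cl)cc4)[nH]c3=O)c2)cc(OC)c1OC`: 2400 nM
- compound 2, `O=C(/C=C/c1cccc(O)c1)c1cccc(-n2cc(-c3ccccc3)[nH]c2=O)c1`: 3080 nM

In a functional assay on OVCAR-3 cells (Homo sapiens) for inhibition (on this read-out lower numbers stand for stronger inhibition of growth and higher numbers for weaker inhibition of growth), compound 1 gives 2400 nM, and compound 2 gives 3080 nM. Compound 1 has the lowest of the two numbers, but the gap to compound 2 lies within the scatter, so nothing separates the pair. Going by the values given here, no step between compounds differing in one place is available, and compound 2 differs from compound 1 in more than one place, so it offers no direct guide.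

Compound 3, `COc1cc(/C=C/C(=O)c2cccc(-n3cc(-c4ccccc4)[nH]c3=O)c2)cc(OC)c1OC`, has not been measured. It differs from compound 1 by hydrogen in place of chloro on an aromatic carbon, the carbon sitting para to a large group. Among the compounds with values here, with no comparable step on record, the change from compound 1 to compound 3 is expected to be small, at most a modest loss, as a 1.3-fold higher number from compound 1 to compound 3 (0.10 log units; within the scatter). In this assay compound 3 is therefore estimated at 3000 nM, within a range from 1200 nM to 7500 nM.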

Compound 3, concentration for 50% growth inhibition: 1230 nM
Estimate against measurement, compound 3: 2.4-fold (0.39 log units) above, and the stated range covers the measured number.
By their numbers in this assay, from the lowest: compounds 3, 1 and 2 (each within the scatter of the next, the first and the last beyond it).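

In this assay, the change from 4-chlorophenyl to phenyl, with hydrogen in place of chloro on an aromatic carbon para to a large group, reads as a 2.0-fold lower number from compound 1 to compound 3 (0.29 log units; within the scatter) and gives the first direct view of this position. The earlier compounds shown here offered no such single change. Growth inhibition holds at the level of compound 1 without the chloro, and the pair cannot be told apart here, while nothing measured on these compounds accounts for the size of this step.

As far as these compounds go, whether another group on this carbon, such as methoxy, an amine or a carboxylic acid, would shift the number beyond the scatter remains open. Also open, from the compounds shown here alone, is what a single change elsewhere in the shared core would do, for instance fluoro in place of one methoxy group.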